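The source may hold more compounds than are shown below. What is called first, only, known or untested is meant among the compounds shown, and "the series" means these compounds.

Working notes on the series. Compound 1 `CO[C@H]1O[C@H](COc2ccc(OC3CCCCC3)cc2)[C@@H](O)[C@H](O)[C@H]1Oc1ccc(C(C)C)cc1` gives 25000 nM in a functional assay on MDA-MB-231 cells (Homo sapiens) for cytotoxicity, read by MTT assay, with a stated time of 48 h; on this read-out lower numbers stand for an effect already at smaller amounts and higher numbers for an effect only at larger amounts of compound. Compound 2 `CO[C@@H]1O[C@H](COc2ccc(-c3ccccc3)cc2)[C@@H](O)[C@H](O)[C@H]1Oc1ccc(OC2CCCCC2)cc1` gives 36000 nM in this assay. Compound 3 `CO[C@H]1O[C@H](COc2ccc(-c3ccccc3)cc2)[C@@H](O)[C@H](O)[C@H]1Oc1ccc(C(C)C)cc1` gives 31000 nM in this assay. The three numbers sit close together: compound 3 lies within the scatter of compound 1 on one side and of compound 2 on the other, so none of the three measured compounds can be set apart from the rest on these data. Within the data shown here, the only step between measured compounds that differ in one place, a 1.2-fold higher number from compound 1 to compound 3 (0.09 log units; within the scatter), was within the scatter, and it concerned a different part of the molecule.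

Compound 4 `CO[C@H]1O[C@H](COc2ccc(-c3ccccc3)cc2)[C@@H](O)[C@H](O)[C@H]1Oc1cccc(C(C)C)c1` is the next member to be measured. Against compound 3 the change is 3-isopropylphenyl in place of 4-isopropylphenyl on an oxygen on a saturated carbon. Among the measured compounds shown here, no measured pair varies the isopropylphenyl part, so there is no step that bears directly on this change; the one step in hand, touching another group, stayed within the scatter, and the whole series so far spans less than the scatter itself.

The number for compound 4 is therefore expected to stay near that of compound 3, with the step of a 1.0-fold lower number from compound 3 to compound 4 (0.01 log units; within the scatter) expected to fall within the scatter. Compound 4 is estimated at 30000 nM, with a range from 12000 nM to 75000 nM.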

Compound 4, half-maximal effective concentration: 30000 nM
The estimate for compound 4 equals the measured number at the digits printed, within the range that was stated.
By their numbers in this assay, from the lowest: compounds 1, 4, 3 and 2 (each within the scatter of the next).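

The isopropylphenyl group on the oxygen on a saturated carbon now has its first direct test: in this assay, the step is a 1.0-fold lower number from compound 3 to compound 4 (0.01 log units; within the scatter), so this pair separates the 3-isopropylphenyl and 4-isopropylphenyl groups by no margin that can be read. Both groups have the same atoms and the same counts, and the rest of the structure is held constant, so this is the only listed step that varies this part of the molecule, and it shows that, with the rest of compound 3 in place, the isopropyl group can be attached at either of these two ring positions without a readable difference in this assay. No accompanying measurement bears on this result.

The compounds shown leave open whether the same holds on another background, such as that of compound 1, where the group on the other side of the core differs. They also leave open whether a ring carrying an amine or a carboxylic acid, or a longer chain in place of isopropyl, would give a step beyond the scatter at this position.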